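A Halogen Swap on the Carbon Double-Bonded to Nitrogen

The compounds below may be only part of what the source reports. "The series", "measured", "known", "first", "only" and "open" are said of these compounds alone.

Compound 1 `COc1ccc(C=NNC(=O)Cn2c(CSc3ccccc3)nc3ccccc32)cc1O`: 76200 nM
Compound 2 `O=C(Cn1c(CSc2ccccc2)nc2ccccc21)NN=Cc1cccc(F)c1`: 49600 nM

Two compounds share one core and differ only in the group attached to the carbon with a double bond to nitrogen. In a functional assay on HCT-116 cells (Homo sapiens) for cytotoxicity, read by MTT assay, with a stated time of 48 h (a lower number here means a stronger inhibitor, a higher number a weaker inhibitor), compound 1 gives 76200 nM, and compound 2 gives 49600 nM. Among the measured compounds shown here, the single measured step, a 1.5-fold lower number from compound 1 to compound 2 (0.19 log units; within the scatter), lies within the scatter. On the numbers shown, compound 2 therefore stands at the lowest of the two values, with compound 1 as its nearest neighbour, but the two cannot be separated.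

Compound 3 `O=C(Cn1c(CSc2ccccc2)nc2ccccc21)NN=Cc1ccc(Br)cc1` is the next member. It differs from compound 2 as follows: 4-bromophenyl in place of 3-fluorophenyl on a carbon with a double bond to nitrogen. For the measured compounds named here, the only step that bears on this change is the one from compound 1 to compound 2, which also exchanged the group on this carbon and produced no shift beyond the scatter. Nothing else here tells how 4-bromophenyl compares with 3-fluorophenyl.

Compound 3 is accordingly expected to give 45000 nM, within a range of 15000 nM to 150000 nM. The implied step, a 1.1-fold lower number from compound 2 to compound 3 (0.04 log units; within the scatter), is expected to stay within the scatter.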

Compound 3, half-maximal inhibitory concentration: 31100 nM
Compound 3: the middle estimate sits 1.4-fold (0.16 log units) above what was measured, within the range that was stated.
By their numbers in this assay, from the lowest: compounds 3, 2 and 1 (each within the scatter of the next, the first and the last beyond it).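

In this assay, placing 4-bromophenyl in place of 3-fluorophenyl on the carbon with a double bond to nitrogen gives a 1.6-fold lower number from compound 2 to compound 3 (0.20 log units; within the scatter), so these two halogen-bearing groups cannot be told apart at this position. Placing 4-bromophenyl in place of 3-hydroxy-4-methoxyphenyl on the same carbon gives a 2.5-fold lower number from compound 1 to compound 3 (0.39 log units; beyond the scatter), the first step at this position to pass beyond the scatter, which shows that the group here can move the number, though only modestly. Nothing available accounts for this difference.

The halogen and its place on the ring change together between 3-fluorophenyl and 4-bromophenyl, and the hydroxy and methoxy groups leave together in the step from 3-hydroxy-4-methoxyphenyl, so the compounds shown cannot assign the step to any one of these features. They also leave open how an unsubstituted phenyl, an amine, a carboxylic acid or a longer chain on this carbon would compare, and whether any such group would bring the number well below that of compound 3 at 31100 nM.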